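The source may report more compounds than this note shows. Statements on the series, on what has been measured and on what is new or still open speak of the compounds shown alone.

Working notes on the series. Compound 3 `COc1ccc(C(=O)N=C(N)N)cc1S(C)(=O)=O` gives 270 nM in a functional assay for inhibition of sodium/hydrogen exchanger (Oryctolagus cuniculus) (on this read-out higher numbers stand for weaker inhibition and lower numbers for stronger inhibition), the highest of the three numbers at hand. Within the data shown here, compound 2 `CS(=O)(=O)c1cc(C(=O)N=C(N)N)ccc1-n1ccnc1` gives 150 nM in this assay, and the one single-point step recorded, a 1.8-fold higher number from compound 2 to compound 3 (0.26 log units; within the scatter), stays within the scatter. Among the measured compounds shown here, compound 1 `Cc1cc(Br)c(C(=O)N=C(N)N)cc1S(C)(=O)=O` gives 70 nM, further away from compound 3 and beyond the scatter, but compound 1 differs from compound 3 in more than one place, so no single step is drawn from that pair.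

Compound 4 `Cc1ccc(C(=O)N=C(N)N)cc1S(C)(=O)=O` is not yet measured. It differs from compound 3 by methyl in place of methoxy on an aromatic carbon. For the measured compounds named here, the only measured step bearing on this position, the exchange at the same aromatic carbon recorded as the step from compound 2 to compound 3, was small, and it swapped a ring for methoxy rather than methoxy for methyl. On that basis the step to compound 4 in this assay is expected to be small, if anything toward a modestly lower number, with the estimated step of a 1.4-fold lower number from compound 3 to compound 4 (0.13 log units; within the scatter). Compound 4 is therefore expected to give about 200 nM in this assay, within a range of 70 nM to 600 nM.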

Compound 4, half-maximal inhibitory concentration: 210 nM
Estimate against measurement, compound 4: 1.1-fold (0.02 log units) below; low and high end bracket the measured number.
By their numbers in this assay, from the lowest: compound 1; then compounds 2, 4 and 3 (each within the scatter of the next).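

In this assay the aromatic carbon ortho to the methylsulfonyl group now carries methoxy, methyl or 1H-imidazol-1-yl, and the two new steps at that position, a 1.3-fold lower number from compound 3 to compound 4 (0.11 log units; within the scatter) and a 1.4-fold higher number from compound 2 to compound 4 (0.15 log units; within the scatter), both stay inside the scatter, so methyl, with no oxygen and no ring, reads the same there. Hydrogen in place of bromo on an aromatic carbon gives a 3.0-fold higher number from compound 1 to compound 4 (0.48 log units; beyond the scatter) and is the first single-place step beyond the scatter, which ties the gap between these two compounds to that one place. Nothing at hand gives a reason for either result.

Going by these compounds, whether an amine, a carboxylic acid or a longer chain at the methoxy position would stay in the same range remains open. Also open, on these data alone, is whether bromo gives a similar step on the core of compound 3 or compound 2.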